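Thioether and ether variants on the shared core: cytotoxicity notes

This account rests on a few compounds, and the source may have more. Where it says the series, first, only, none or still open, it means among the compounds named here.

Compound 1 `Nc1nc(OCC(F)(F)F)c2ncn(/C=C3/CC3(CO)CO)c2n1`: > 20000 nM, a limit of the test
Compound 2 `CC(C)CSc1nc(N)nc2c1ncn2/C=C1/CC1(CO)CO`: > 20000 nM, a limit of the test
Compound 3 `Nc1nc(OCc2ccccc2)c2ncn(/C=C3/CC3(CO)CO)c2n1`: > 20000 nM, a limit of the test

In an ADME assay on BCBL1 cells (Homo sapiens) for cytotoxicity, with a stated time of 7 days (on this read-out higher numbers stand for lower toxicity in this test and lower numbers for higher toxicity in this test), compound 1 stands only at a limit, > 20000 nM. The same holds across the small set: the limit of > 20000 nM in this assay, at which 3 of the 3 values shown sit. Compound 4 `CCCCCCSc1nc(N)nc2c1ncn2/C=C1/CC1(CO)CO` differs from compound 1 in one place, (hexylsulfanyl in place of 2,2,2-trifluoroethoxy on an aromatic carbon). The measured steps that bear on such an exchange at that carbon are a step that the two limits leave unreadable from compound 1 to compound 2 and a step that the two limits leave unreadable from compound 1 to compound 3; both run between limits and so give no readable size. No step beyond the scatter is therefore expected for a step that the limit leaves unreadable from compound 1 to compound 4. Compound 4 is estimated at 25000 nM, with a range from 8000 nM to 60000 nM, most probably reported once more as a limit.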

Compound 4, half-maximal cytotoxic concentration: > 20000 nM
Compound 4: a limit, no number; the forecaster's own chance of this, stated with the estimate: 75%; the middle value lies beyond the limit too.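

The steps from compound 1, compound 2 and compound 3 to compound 4 cannot be read, as all four values are limits: the limit of > 20000 nM in this assay, at which 4 of the 4 values shown sit.

Going by these compounds, whether any exchange at that aromatic carbon changes cytotoxicity in this assay remains open.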